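The compounds below may be only part of what the source reports. "The series", "measured", "known", "first", "only" and "open" are said of these compounds alone.

Three close relatives share one core: compound 1 `CCCSc1nc(Cc2c(F)cccc2Cl)c(C)c(=O)[nH]1`, compound 2 `Cc1c(C(C)c2c(F)cccc2Cl)nc(SC(C)C)[nH]c1=O` and compound 3 `CCCSc1nc(C(C)c2c(F)cccc2Cl)c(C)c(=O)[nH]1`. All three were tested in an ADME assay on MT4 cells (Homo sapiens) for activation, read by MTT assay; a higher number here means that more compound is tolerated, a lower number that less compound is tolerated. Compound 1 gives > 76000 nM, which is a limit and not a number. Compound 2 gives > 15000 nM, which is also a limit. Compound 3 gives > 1500 nM, again a limit, so its standing can be told only as that limit.

Compound 4 `CCCSc1nc(C(C)c2c(F)cccc2F)c(C)c(=O)[nH]1` changes one atom of compound 3: fluoro in place of chloro on an aromatic carbon. In words, this is fluoro in place of chloro on an aromatic carbon.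

Two measured changes lead to compound 3. Methyl in place of hydrogen on a saturated chain carbon bound to two aromatic carbons gives a step that the two limits leave unreadable from compound 1 to compound 3. Propyl in place of isopropyl on a sulfur gives a step that the two limits leave unreadable from compound 2 to compound 3. Neither exchanges one halogen for another, and neither has a readable size, so no particular direction or size of change can be carried over to this assay.

For compound 2 the limit of > 15000 nM is the middle one of the three, and the expectation is set near it. The estimated step is a step that the limit leaves unreadable from compound 3 to compound 4, and it is only nominal, as it starts from a limit. Compound 4 is expected to read about 15000 nM, with an estimated range of 1500 nM to 80000 nM.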

Compound 4, half-maximal cytotoxic concentration: > 3000 nM
Compound 4: only a limit was reported (the forecaster's own chance of this, stated with the estimate: 75%); the middle value is on the limit's open side.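

Going by these compounds alone, compound 3 and compound 4 are both reported only as limits, so putting fluoro in place of chloro gives no step that can be read, in either size or direction. The compounds shown leave open what actual value any of them would reach in this assay, and whether any single change among them shifts it.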